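Bromo to tert-butyl at the benzyl end of the side chain

This account rests on a few compounds, and the source may have more. Where it says the series, first, only, none or still open, it means among the compounds named here.

compound 1 `O=c1nc(N2CCN(NC3CCCCC3)CC2)sc2c([N+](=O)[O-])cc(C(F)(F)F)cc12` — > 64 ug/mL
compound 2 `O=c1nc(N2CCN(NCc3ccc(Br)cc3)CC2)sc2c([N+](=O)[O-])cc(C(F)(F)F)cc12` — > 64 ug/mL

In an ADME assay on Vero cells (Chlorocebus sabaeus) for cytotoxicity, read by MTT assay, with a stated time of 72 h (a higher number here means that more compound is tolerated, a lower number that less compound is tolerated), compound 1 gives > 64 ug/mL, which is a limit of the assay and not a number. In this assay compound 2 gives > 64 ug/mL, likewise a limit. Both values therefore sit at the limit of > 64 ug/mL in this assay, at which 2 of the 2 values shown sit, and the step that the two limits leave unreadable from compound 1 to compound 2 cannot be read from these two limits; whether exchanging cyclohexyl for 4-bromobenzyl on the amine nitrogen moved the tolerated concentration at all is not known.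

Compound 3 `CC(C)(C)c1ccc(CNN2CCN(c3nc(=O)c4cc(C(F)(F)F)cc([N+](=O)[O-])c4s3)CC2)cc1` differs from compound 2 by tert-butyl in place of bromo on an aromatic carbon. Among the measured compounds shown here, the only measured step bearing on this change, from compound 1 to compound 2, is unreadable in size, so nothing among the measured compounds points to a shift in either direction, and the single readable fact is that both measured compounds stand at the same limit. Compound 3 is accordingly expected to give 64 ug/mL in this assay, in a range of 32 ug/mL to 150 ug/mL. The step of a number no higher from compound 2 to compound 3 (the limit leaves the size open) implied by this estimate is expected to be none beyond the scatter, with another limit the most probable outcome.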

Compound 3, half-maximal cytotoxic concentration: > 64 ug/mL
Compound 3 gave a limit, no number (the forecaster's own chance of this, stated with the estimate: 75%); the middle value lies on the limit itself.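

In this assay compound 3 gives > 64 ug/mL which is again a limit and not a number. Among the compounds shown here, no step among compound 1, compound 2 and compound 3 can be read, because all three stand at the same limit: the limit of > 64 ug/mL in this assay, at which 3 of the 3 values shown sit. The compounds shown leave open whether cyclohexyl, 4-bromobenzyl and 4-(tert-butyl)benzyl differ at all in the concentration tolerated.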